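Chloro for bromo on the anilino ring of compound 3

The compounds below may be only part of what the source reports. "The series", "measured", "known", "first", "only" and "open" are said of these compounds alone.

Measured so far:
Compound 1, `Cc1n[nH]c2ccc(-c3nc4cnc(N5CCN(C)CC5)cn4c3Nc3ccc(I)cc3)cc12`, 0%
Compound 2, `Cc1n[nH]c2ccc(-c3nc4cnc(N5CCN(C)CC5)cn4c3Nc3ccc(Cl)cc3F)cc12`, 0%
Compound 3, `Cc1n[nH]c2ccc(-c3nc4cnc(N5CCN(C)CC5)cn4c3Nc3ccc(Br)cc3Cl)cc12`, 70.5%

In a functional assay on MV4-11 cells (Homo sapiens) for inhibition, with a stated time of 120 h, tested at 10 uM (on this read-out lower numbers stand for less inhibition and higher numbers for more inhibition at the one concentration tested (going by the name of the read-out)), compound 3 stands highest of the three numbers; its nearest neighbour is compound 1 and its furthest is compound 2, both beyond the scatter below it. Compound 4, `Cc1n[nH]c2ccc(-c3nc4cnc(N5CCN(C)CC5)cn4c3Nc3ccc(Cl)cc3Cl)cc12`, has not yet been measured. The change from compound 3 to compound 4 is chloro in place of bromo on an aromatic carbon.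

Among the measured compounds shown here, no measured step isolates a chloro for a bromo at this place. For the measured compounds named here, the steps that bear on it are a number 70.5 percentage points higher from compound 1 to compound 3 (beyond the scatter) and a number 70.5 percentage points higher from compound 2 to compound 3 (beyond the scatter), both large. Each of them alters two halogens at once, so the separate share of the bromo cannot be read from them. Compound 2, which carries a 4-chloro-2-fluorophenyl, gives 0%, a reminder that a chloro on this ring does not by itself secure the inhibition seen with compound 3. Compound 4 is therefore expected to keep some of the inhibition of compound 3, with a step of a number 25.5 percentage points lower from compound 3 to compound 4 (beyond the scatter) expected in this assay, downward but uncertain. Compound 4 is estimated at 45%, within a range of 5% to 80%.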

Compound 4, a percentage reported as inhibition, at one concentration (the size of the read-out at that concentration, not a potency): 78.8%
Beside the measured number, compound 4's estimate is 33.8 percentage points below it; low and high end bracket the measured number.
By their numbers in this assay, from the lowest: compounds 1 and 2 (each within the scatter of the next); then compounds 3 and 4 (each within the scatter of the next).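

In this assay, the swap at this place gives a number 8.3 percentage points higher from compound 3 to compound 4 (within the scatter), so with the chloro group meta to it in place, bromo and chloro cannot be told apart on this read-out. The step that isolates the other halogen is chloro in place of fluoro, a number 78.8 percentage points higher from compound 2 to compound 4 (beyond the scatter), which shows that the read-out turns on that halogen while chloro stands at the place para to the large group, and the step of a number 78.8 percentage points higher from compound 1 to compound 4 (beyond the scatter), with 2,4-dichlorophenyl in place of 4-iodophenyl, changes both places at once and cannot divide its size between them. Nothing given here accounts for these steps.

The compounds shown leave open whether a methyl, a methoxy or a trifluoromethyl group at this place would keep the inhibition, and whether iodo would do so with the chloro group meta to it retained. They also leave open how compound 3 and compound 4 would compare at other concentrations, since a single concentration gives no potency and may hide a difference between them.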